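Indole-2-carboxamide series: acrylamide to propanamide at the anilide

The source may hold more compounds than are shown below. What is called first, only, known or untested is meant among the compounds shown, and "the series" means these compounds.

Measured compounds in a functional assay on RAW264.7 cells (Mus musculus) for inhibition, read by ELISA, with stated times of 30 min and 24 h; a higher number here means a weaker inhibitor, a lower number a stronger inhibitor:
compound 1, `CN1CCN(c2ccc(NC(=O)c3cc4cc(NC(=O)CCl)ccc4n3Cc3ccc(C(F)(F)F)cc3)cc2)CC1`, 2990 nM
compound 2, `C=CC(=O)Nc1ccc2c(c1)cc(C(=O)Nc1ccc(N3CCN(C)CC3)cc1)n2Cc1ccc(C(F)(F)F)cc1`, 6280 nM

Going by the values given here, compound 2 gives the highest of the two numbers so far in this assay; its nearest neighbour is compound 1, and the step of a 2.1-fold higher number from compound 1 to compound 2 (0.32 log units; beyond the scatter) is the only measured step. It changed the same carbonyl-bound group that is changed again here.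

Compound 3, `CCC(=O)Nc1ccc2c(c1)cc(C(=O)Nc1ccc(N3CCN(C)CC3)cc1)n2Cc1ccc(C(F)(F)F)cc1`, differs from compound 2 in one place: ethyl in place of vinyl on a carbonyl carbon. The ethyl group that enters has no double bond outside aromatic rings, so the group on this carbonyl carbon loses the feature it had in both compound 2 and compound 1.

Among the compounds with values here, no measured step bears directly on vinyl becoming ethyl. Within the data shown here, the one step available shows that altering this carbonyl-bound group moved the number modestly. A step beyond the scatter in this assay, toward a higher number, is expected for compound 3, with a wide range; the expected step is a 2.4-fold higher number from compound 2 to compound 3 (0.38 log units; beyond the scatter). Compound 3 is estimated at 15000 nM, between 4500 nM and 50000 nM.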

Compound 3, half-maximal inhibitory concentration: 3330 nM
Compound 3: the middle estimate sits 4.5-fold (0.65 log units) above what was measured; the whole stated range lies above it.
By their numbers in this assay, from the lowest: compounds 1, 3 and 2 (each within the scatter of the next, the first and the last beyond it).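

In this assay, ethyl in place of vinyl on a carbonyl carbon gives (a 1.9-fold lower number from compound 2 to compound 3 (0.28 log units; within the scatter)), so the double bond outside aromatic rings on this group can be lost with no change that can be read. Methyl in place of chloro on a saturated chain carbon bound to a carbonyl carbon gives (a 1.1-fold higher number from compound 1 to compound 3 (0.05 log units; within the scatter)), so compound 3 and compound 1 cannot be told apart either, and the earlier step (a 2.1-fold higher number from compound 1 to compound 2 (0.32 log units; beyond the scatter)) now stands as the only one of the three beyond the scatter, and only just. Among these three compounds, then, neither the vinyl nor the chloro group is needed for a number in this range, and nothing measured on these compounds offers an explanation for the steps.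

Open, as far as these compounds go, is whether a longer chain, a ring such as cyclopropyl, or an amine such as dimethylaminomethyl on this carbonyl carbon would move the number beyond the scatter in this assay, or whether this group matters little across all its forms. Also open, from the compounds shown here alone, is how much of the number depends on the rest of the structure, which all three compounds share, including the 4-methylpiperazine and the trifluoromethyl group.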